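This account rests on a few compounds, and the source may have more. Where it says the series, first, only, none or still open, it means among the compounds named here.

In a functional assay on A-375 cells (Homo sapiens) for inhibition, read by MTT assay, with a stated time of 48 h (on this read-out higher numbers stand for weaker inhibition and lower numbers for stronger inhibition), compound 1 `CCO[C@H]1C=C[C@H]2C/C=C\C[C@H](c3ccc(Cl)cc3)OC(=O)C[C@@H]1O2` gives 4900 nM. Compound 2 `CO[C@H]1C=C[C@H]2C/C=C\C[C@H](c3ccc(Br)cc3)OC(=O)C[C@@H]1O2` gives 5450 nM, and compound 3 `COc1ccc(CO[C@H]2C=C[C@H]3C/C=C\C[C@H](c4ccc(F)cc4)OC(=O)C[C@@H]2O3)cc1` gives 4760 nM. These three numbers lie within the usual scatter of one another, so compound 1 stands level with both, even though each pair differs in more than one place. Compound 4 `CCO[C@H]1C=C[C@H]2C/C=C\C[C@H](c3ccc(OC)cc3)OC(=O)C[C@@H]1O2` keeps the core of compound 1 and makes a single change, methoxy in place of chloro on an aromatic carbon. Among the measured compounds shown here, no measured pair isolates this change, so no shift beyond the scatter is expected in this assay, in either direction. The expected step, a 1.1-fold higher number from compound 1 to compound 4 (0.05 log units; within the scatter), stays within the scatter. The estimate for compound 4 is 5500 nM, expected to fall between 2500 nM and 12000 nM.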

Compound 4, half-maximal inhibitory concentration: 62700 nM
Compound 4: middle estimate off by 11-fold (1.06 log units), on the low side, and the stated range ends below it.
By their numbers in this assay, from the lowest: compounds 3, 1 and 2 (each within the scatter of the next); then compound 4.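

In this assay, among the compounds shown here, the single swap of chloro for methoxy on this aromatic carbon gives a 13-fold higher number from compound 1 to compound 4 (1.11 log units; beyond the scatter) and so a much weaker inhibitor. The earlier compounds shown here differ in more than one place and could not show that this position responds so strongly to one change. No evidence here gives a reason for this loss.

As far as these compounds go, this is one pair on one core, so it remains open whether the loss would carry over to other cores. From the compounds shown here alone, how an amine, a carboxylic acid or a longer chain such as ethoxy would fare in this place also stays open.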